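A few compounds are considered here, and "the series" means these few. Any claim that something is new, unique, unknown or untested is made for them only; others in the source may bear on it.

In an ADME assay on MDCK cells (Canis lupus familiaris) for cytotoxicity, read by MTT assay, with a stated time of 24 h (a lower number here means that less compound is tolerated, a higher number that more compound is tolerated), three compounds on a shared core have been measured. Compound 1 `N#CCCN(Cc1cccs1)S(=O)(=O)c1ccccc1F` reads > 205000 nM, and this value is a limit of the assay. Compound 2 `Cc1ccc(S(=O)(=O)N(CCC#N)Cc2cccs2)cc1` gives a true number of 127000 nM. Compound 3 `COc1ccc(S(=O)(=O)N(CCC#N)Cc2cccs2)cc1` reads > 198000 nM, which is also a limit of the assay, so compound 3 stands on a limit and not on a number.

Compound 4 `N#CCCN(Cc1cccs1)S(=O)(=O)c1ccc(N)cc1` differs from compound 3 by amino in place of methoxy on an aromatic carbon, with amino in place of methoxy on an aromatic carbon. Among the compounds with values here, two measured steps bear on this change. The first is an at least 1.6-fold lower number from compound 1 to compound 2 (0.20 log units; that floor lies within the scatter), and the second, an exchange on the same aromatic carbon, is an at least 1.5-fold higher number from compound 2 to compound 3 (0.19 log units; that floor lies within the scatter). With that second step as the nearer guide, no change beyond the scatter is expected in this assay. The expected step, leaning slightly downward, is an at least 1.3-fold lower number from compound 3 to compound 4 (0.12 log units; that floor lies within the scatter). For compound 4 the estimated value is 150000 nM, with an expected range from 70000 nM to 300000 nM.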

Compound 4, half-maximal cytotoxic concentration: > 207000 nM
Compound 4: a limit, no number (the forecaster's own chance of this, stated with the estimate: 40%); at least 1.3-fold (0.13 log units) between middle value and limit.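

In this assay compound 4 gives > 207000 nM, which is a limit of the assay and not a number. Amino on this aromatic carbon, para to a large group, thus joins methoxy in compound 3 in reaching a limit, whereas methyl in compound 2 alone gives a true number, and the comparison with methyl is an at least 1.6-fold higher number from compound 2 to compound 4 (0.21 log units; that floor lies within the scatter). The steps to compound 4 from compound 3 and from compound 1 join limit to limit and cannot be read, so the exchange of methoxy for amino has no measurable size here.

Going by these compounds, whether compound 3 and compound 4 differ at all remains open. Also open, on these data alone, is whether a carboxylic acid or a dimethylamino group on this carbon would give a true number in this assay or another limit.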